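A few compounds are considered here, and "the series" means these few. Any claim that something is new, unique, unknown or untested is made for them only; others in the source may bear on it.

Measured so far in a functional assay on membranes from Sf9 cells for agonist activity at histamine H2 receptor (Homo sapiens), read by scintillation counting and GTPgammaS binding, with a stated time of 90 min; on this read-out lower numbers stand for an effect already at smaller amounts and higher numbers for an effect only at larger amounts of compound:
compound 1 `Cc1nc(N)sc1CCCN/C(N)=N/C(=O)NCC(C)CCc1ccccc1` — 29.5 nM
compound 2 `CCCNC(=O)/N=C(\N)NCCCc1sc(N)nc1C` — 178 nM
compound 3 `Cc1nc(N)sc1CCCN/C(N)=N/C(=O)NCc1ccccc1` — 28.8 nM

Compound 3 shows the lowest number of the three, but its gap to compound 1 is within the scatter, so the two cannot be ordered; only compound 2 stands apart, beyond the scatter from both.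

Compound 4 `Cc1nc(N)sc1CCCN/C(N)=N/C(=O)NCC(C)CC1CCCCC1` is not yet measured. It differs from compound 3 in one place: 1-(cyclohexylmethyl)ethyl in place of phenyl on a saturated chain carbon bound to an amide-type nitrogen. The new group is a branched chain carrying a saturated ring, whereas compound 1 carries a branched chain ending in an aromatic ring.

For the measured compounds named here, two measured steps bear on this. a 6.0-fold higher number from compound 1 to compound 2 (0.78 log units; beyond the scatter) shows a higher number where hydrogen stands in place of phenethyl. a 6.2-fold lower number from compound 2 to compound 3 (0.79 log units; beyond the scatter) shows that putting an aromatic ring back on the chain lowered it again by a similar amount. Going by the values given here, both steps point the same way: a longer chain ending in a ring gives the lower numbers, and the data give no step separating aromatic from saturated rings.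

Compound 4 is therefore expected to sit close to compound 1 and compound 3, with the step of a 1.0-fold higher number from compound 3 to compound 4 (0.02 log units; within the scatter) expected to stay within the scatter. The estimate for compound 4 in this assay is 30 nM, with a range from 10 nM to 90 nM.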

Compound 4, half-maximal effective concentration: 17.4 nM
Compound 4: the middle estimate sits 1.7-fold (0.24 log units) above what was measured; the range from low to high includes it.
By their numbers in this assay, from the lowest: compounds 4, 3 and 1 (each within the scatter of the next); then compound 2.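

In this assay the saturated ring serves as well as the aromatic one at this position: a 1.7-fold lower number from compound 1 to compound 4 (0.23 log units; within the scatter) is within the scatter, so cyclohexyl in place of benzyl on a saturated chain carbon, three bonds along the chain from an amide-type nitrogen, gives no difference that can be claimed. The change from compound 3 is read the same way, since a 1.7-fold lower number from compound 3 to compound 4 (0.22 log units; within the scatter) also stays within the scatter with 1-(cyclohexylmethyl)ethyl in place of phenyl on a saturated chain carbon bound to an amide-type nitrogen. Against the compound without a ring, a 10-fold lower number from compound 2 to compound 4 (1.01 log units; beyond the scatter) lies beyond the scatter with cyclohexylmethyl in place of hydrogen on a saturated chain carbon bound to two saturated chain carbons, so among these compounds an aromatic ring is not needed for the lower numbers.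

Still open, on these data alone, is whether a hydroxyl or an amine on the cyclohexyl ring, a cyclopentyl ring in its place, or a longer chain leading to it would stay level with compound 4. The shared core also remains unvaried here, and nothing on hand gives a reason for any of these values.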